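The source may report more compounds than this note shows. Statements on the series, on what has been measured and on what is new or still open speak of the compounds shown alone.

The shared core carries a secondary amine bearing a substituted methyl group, and three of its variants have numbers in an ADME assay on MDCK cells (Canis lupus familiaris) for cytotoxicity, read by microscopy, with a stated time of 48 h; on this read-out lower numbers stand for higher toxicity in this test and higher numbers for lower toxicity in this test. Compound 1, `CCc1ccc(CN[C@@H]2C[C@H]3C[C@@H]([C@H]2C)C3(C)C)s1`, gives 1560 nM in this assay. Compound 2, `CCCc1csc(CN[C@@H]2C[C@H]3C[C@@H]([C@H]2C)C3(C)C)c1`, gives 12500 nM in this assay, a higher number than compound 1 and a gap beyond the scatter. Compound 3, `C[C@H]1[C@H](NCc2cncnc2)C[C@H]2C[C@@H]1C2(C)C`, does not give a number in this assay at all: its value of > 100000 nM is a limit of the assay, and the limit of > 100000 nM in this assay, at which 1 of the 3 values shown sits, describes where it sits. Among the two numbers actually reported, compound 1 therefore stands at the lowest one, meaning the highest toxicity in this test.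

Compound 4, `C[C@H]1[C@H](NCc2cccs2)C[C@H]2C[C@@H]1C2(C)C`, has not yet been measured in this assay. It differs from compound 1 in one place: hydrogen in place of ethyl on an aromatic carbon. For the measured compounds named here, no step between two measured compounds of this set involves exactly this change, so the data give no measured size for it. The step from compound 1 to compound 4 is expected to be a 2.6-fold higher number from compound 1 to compound 4 (0.41 log units; beyond the scatter), a modest move toward a higher number, within reach of the scatter. Compound 4 is thus estimated to give 4000 nM in this assay, with a range from 1500 nM to 15000 nM.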

Compound 4, minimum cytotoxic concentration: 25000 nM
Compound 4: middle estimate off by 6.3-fold (0.80 log units), on the low side, and the stated range ends below it.
By their numbers in this assay, from the lowest: compound 1; then compounds 2 and 4 (each within the scatter of the next). At a limit, above all of these: compound 3.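

In this assay, hydrogen in place of ethyl on the aromatic carbon next to the ring sulfur gives a 16-fold higher number from compound 1 to compound 4 (1.20 log units; beyond the scatter), so the ethyl group at this place goes with a much lower number than a bare ring carbon does. Hydrogen in place of propyl gives only a 2.0-fold higher number from compound 2 to compound 4 (0.30 log units; within the scatter), so among these compounds the large step belongs to the ethyl group of compound 1 and not to every alkyl group on the ring, although two steps cannot establish a rule. The ring also counts, since thiophen-2-yl in place of pyrimidin-5-yl gives an at least 4.0-fold lower number from compound 3 to compound 4 (0.60 log units; beyond the scatter), a size known only as a bound.

As far as these compounds go, compound 3 has no exact number here, and how far it truly lies from the others stays open, as its value is a limit of the assay: the limit of > 100000 nM in this assay, at which 1 of the 4 values shown sits. Also open, from the compounds shown here alone, is whether a methyl group, a longer chain or an amine on the same ring carbon would bring the number back toward that of compound 1, and whether an ethyl group on the pyrimidin-5-yl ring would have any comparable effect.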